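Thiourea aryl substituent: methyl exchanged for methoxy

The source may hold more compounds than are shown below. What is called first, only, known or untested is meant among the compounds shown, and "the series" means these compounds.

Measured so far in an assay on brain for binding affinity to adenosine receptor A1 (Rattus norvegicus), read by radioligand binding; on this read-out lower numbers stand for stronger inhibition and higher numbers for weaker inhibition:
compound 1, `CCCn1c(=O)c2nc(-c3ccc(OCC(=O)NCCN=C(S)Nc4ccc(N=C=S)cc4)cc3)[nH]c2n(CCC)c1=O`, 6.6 nM
compound 2, `CCCn1c(=O)c2nc(-c3ccc(OCC(=O)NCCN=C(S)Nc4ccc(C)cc4)cc3)[nH]c2n(CCC)c1=O`, 16 nM

Within the data shown here, compound 2 stands at the higher of the two numbers; its only neighbour is compound 1, and the step of a 2.4-fold higher number from compound 1 to compound 2 (0.38 log units; beyond the scatter) is modest. Compound 3 is `CCCn1c(=O)c2nc(-c3ccc(OCC(=O)NCCN=C(S)Nc4ccc(OC)cc4)cc3)[nH]c2n(CCC)c1=O`; it differs from compound 2 by methoxy in place of methyl on an aromatic carbon. Among the measured compounds shown here, no measured step exchanges one of these two groups; the single known step concerns a different group at the same place and gives no direction for this one. The expectation for compound 3 in this assay is therefore a step of a 1.1-fold lower number from compound 2 to compound 3 (0.06 log units; within the scatter), essentially none beyond the scatter. Compound 3 is estimated at 14 nM, range 5 nM to 40 nM.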

Compound 3, inhibition constant: 33.2 nM
Compound 3: middle estimate off by 2.4-fold (0.38 log units), on the low side; low and high end bracket the measured number.
By their numbers in this assay, from the lowest: compound 1; then compound 2; then compound 3.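

In this assay, the exchange of 4-methylphenyl for 4-methoxyphenyl gives a 2.1-fold higher number from compound 2 to compound 3 (0.32 log units; beyond the scatter), so this position also responds to a change between two small groups. The widest span among the three substituents is a 5.0-fold higher number from compound 1 to compound 3 (0.70 log units; beyond the scatter), with isothiocyanate giving the lowest number, methoxy the highest and methyl in between. No evidence on the cause of these differences is available.

A longer ethoxy chain or a chlorine at this place could show how far the trend extends. On these data alone, how a hydroxyl or an amine would compare also remains open.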